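The source may hold more compounds than are shown below. What is called first, only, known or untested is meant among the compounds shown, and "the series" means these compounds.

Compound 2 `CCc1ccc2nc(C(=O)Nc3c(F)cc(-c4cccc(F)c4)cc3F)c(C)c(O)c2c1` stands second highest of the three numbers in a functional assay on Hep 3B2 cells (Homo sapiens) for antiproliferative activity, read by MTT assay, with a stated time of 24 h, tested at 100 ug/mL; a higher number here means a stronger effect of the compound at the concentration tested, a lower number a weaker effect: compound 2 gives 63.2%, its nearest neighbour compound 1 `Cc1ccc2nc(C(=O)Nc3c(F)cc(-c4cccc(F)c4)cc3F)c(C)c(O)c2c1` gives 68.3%, and compound 3 `CCOc1ccc2nc(C(=O)Nc3c(F)cc(-c4cccc(F)c4)cc3F)c(C)c(O)c2c1` gives 33.3%. The step of a number 5.1 percentage points lower from compound 1 to compound 2 (within the scatter) lies within the scatter, whereas a number 29.9 percentage points lower from compound 2 to compound 3 (beyond the scatter) and a number 35 percentage points lower from compound 1 to compound 3 (beyond the scatter) lie beyond it. Compound 4 `Cc1c(C(=O)Nc2c(F)cc(-c3cccc(F)c3)cc2F)nc2ccc(OC(F)(F)F)cc2c1O` differs from compound 2 by trifluoromethoxy in place of ethyl on an aromatic carbon. The step of a number 29.9 percentage points lower from compound 2 to compound 3 (beyond the scatter), in which an oxygen-linked group likewise replaced an alkyl group on an aromatic carbon, bears most closely on this change, and a number 35 percentage points lower from compound 1 to compound 3 (beyond the scatter) points the same way; a fall beyond the scatter is therefore expected, a number 25.2 percentage points lower from compound 2 to compound 4 (beyond the scatter). Compound 4 is accordingly estimated at 38%, with a range of 20% to 58% in this assay.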

Compound 4, a percentage reported as inhibition, at one concentration (the size of the read-out at that concentration, not a potency): 80.3%
Compound 4: middle estimate off by 42.3 percentage points, on the low side; measured number above the stated range.
By their numbers in this assay, from the lowest: compound 3; then compounds 2 and 1 (each within the scatter of the next); then compound 4.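

In this assay, an oxygen-linked group on this aromatic carbon does not by itself lower the number: with trifluoromethoxy the change runs upward (a number 17.1 percentage points higher from compound 2 to compound 4 (beyond the scatter) and a number 12 percentage points higher from compound 1 to compound 4 (beyond the scatter)), and compound 4 stands highest of the four. The fall seen with ethoxy is thus not shared by every oxygen-linked group, since replacing only the ethyl on that oxygen with trifluoromethyl gives a number 47 percentage points higher from compound 3 to compound 4 (beyond the scatter) in the same assay. As far as these compounds go, whether a methoxy group or a chlorine atom here would track compound 3 or compound 4 remains open. No measurement given here accounts for the difference between ethoxy and trifluoromethoxy.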